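Methoxy to Hydroxy on the Pyridine of Compound 2

A few compounds are considered here, and "the series" means these few. Any claim that something is new, unique, unknown or untested is made for them only; others in the source may bear on it.

Compound 2 `COc1cc(-c2nc(C(c3ccc(F)cc3)c3ccc(F)cc3)sc2CC(=O)O)ccn1` gives 29 nM in an in vitro assay on HEK385-7 cells for displacement of a labelled ligand from prostaglandin D2 receptor 2 (Homo sapiens) (on this read-out lower numbers stand for stronger inhibition and higher numbers for weaker inhibition), the lower of the two numbers shown, while compound 1 `N#Cc1cc(-c2nc(C(c3ccc(F)cc3)c3ccc(F)cc3)sc2CC(=O)O)ccc1F` gives 57 nM; the step is a 2.0-fold lower number from compound 1 to compound 2 (0.29 log units; within the scatter). Compound 3 `O=C(O)Cc1sc(C(c2ccc(F)cc2)c2ccc(F)cc2)nc1-c1ccnc(O)c1` carries hydrogen in place of methyl on an oxygen on an aromatic ring. No measured step bears on this change: the only step shown, from compound 1 to compound 2, concerns a different aromatic group and stays within the scatter. Compound 3 is therefore expected to give 60 nM in this assay, with a range of 15 nM to 250 nM. The step of a 2.1-fold higher number from compound 2 to compound 3 (0.32 log units; beyond the scatter) is estimated to lie near the scatter.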

Compound 3, half-maximal inhibitory concentration: 68 nM
Compound 3: middle estimate off by 1.1-fold (0.05 log units), on the low side; the measured number falls inside the stated range.
By their numbers in this assay, from the lowest: compounds 2, 1 and 3 (each within the scatter of the next, the first and the last beyond it).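

On the pyridine, hydrogen in place of methyl on the oxygen gives a 2.3-fold higher number from compound 2 to compound 3 (0.37 log units; beyond the scatter) in this assay, the only step among these compounds that lies beyond the scatter, though it is modest. The 2-hydroxypyridin-4-yl group in place of 3-cyano-4-fluorophenyl gives a 1.2-fold higher number from compound 1 to compound 3 (0.08 log units; within the scatter), so this pair cannot be told apart.

As far as these compounds go, whether an ethoxy group or an amine on this carbon would stay with the methoxy or the hydroxy number remains open. Nothing measured here explains the gap between methoxy and hydroxy.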